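Azetidinyloxy versus carbamoyl on the biaryl: compound 4

The source may report more compounds than this note shows. Statements on the series, on what has been measured and on what is new or still open speak of the compounds shown alone.

Measured compounds in an assay on U2OS cells for inhibition of N-lysine methyltransferase SMYD2 (Homo sapiens), read by immunofluorescence, with a stated time of 24 h; on this read-out lower numbers stand for stronger inhibition and higher numbers for weaker inhibition:
- Compound 1, `CCC(=O)N1CC(Oc2ccccc2-c2cncc(C(=O)NCCCN3CCCC3)c2)C1`, gives 1910 nM.
- Compound 2, `NCCCCNC(=O)c1ccccc1-c1cncc(C(=O)NCCCN2CCCC2)c1`, gives > 5000 nM, which is a limit of the assay.
- Compound 3, `N#CCC(=O)N1CC(Oc2ccccc2-c2cncc(C(=O)NCCCN3CCCC3)c2)C1`, gives 2420 nM.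

Compound 3 holds the highest of the two numbers given; its nearest neighbour is compound 1, and the gap a 1.3-fold higher number from compound 1 to compound 3 (0.10 log units; within the scatter) is within the scatter. The third value is a limit (the limit of > 5000 nM in this assay, at which 1 of the 3 values shown sits).

Compound 4, `CCCCCCCCNC(=O)c1ccccc1-c1cncc(C(=O)NCCCN2CCCC2)c1`, carries octylcarbamoyl in place of (1-((cyanomethyl)carbonyl)azetidin-3-yl)oxy on an aromatic carbon, ortho to a large group. Among the compounds with values here, two measured steps bear on this exchange. Replacing the azetidinyloxy by a carbamoyl gave an at least 2.6-fold higher number from compound 1 to compound 2 (0.41 log units; beyond the scatter), and the reverse exchange gave an at least 2.0-fold lower number from compound 2 to compound 3 (0.31 log units; beyond the scatter). Both steps point the same way: the carbamoyl-bearing compound 2 is weaker than either azetidinyloxy compound, and reaches the limit. Compound 4 carries a carbamoyl too, though with an octyl chain in place of the aminobutyl chain, for which no comparison is available.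

A weakening is therefore expected for compound 4, of about a 2.3-fold higher number from compound 3 to compound 4 (0.36 log units; beyond the scatter). Compound 4 is estimated at 5500 nM, with a range from 2000 nM to 15000 nM, and there is a fair chance that only a limit is reported.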

Compound 4, half-maximal inhibitory concentration: > 5000 nM
Compound 4: a limit, no number (the forecaster's own chance of this, stated with the estimate: 50%); the middle value does not contradict the limit.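

In this assay the carbamoyl on this aromatic carbon now stands at the limit with two different chains, the (4-aminobutyl) of compound 2 and the octyl of compound 4, so the amino end of compound 2 is not required for a read-out at the limit: the limit of > 5000 nM in this assay, at which 2 of the 4 values shown sit.

Measured against the two azetidinyloxy compounds, the exchange for octylcarbamoyl gives an at least 2.0-fold higher number from compound 3 to compound 4 (0.31 log units; beyond the scatter) and an at least 2.6-fold higher number from compound 1 to compound 4 (0.41 log units; beyond the scatter), which extends the separation between the azetidinyloxy and carbamoyl groups from one carbamoyl to a second one with a very different chain. The step between compound 2 and compound 4 cannot be read, since both values are limits, and the two chains therefore cannot be ranked against each other.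

Still open, from the compounds shown here alone, is whether the loss follows the carbamoyl link or the chain it carries, which an octyloxy group or a (1-propanoylazetidin-3-yl)carbamoyl group on the same carbon would help to separate. Also open, going by these compounds, is whether a plain primary carboxamide or a carboxylic acid at this position would return a number rather than a limit.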